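Sulfur in Place of Oxygen on a Shared Core

A few compounds are considered here, and "the series" means these few. Any claim that something is new, unique, unknown or untested is made for them only; others in the source may bear on it.

Compound 3 `Nc1cc(N)c2nc(-c3ccccc3)c(Oc3ccc(F)cc3)nc2c1` gives 69200 nM in a functional assay on UACC-62 cells (Homo sapiens) for inhibition, read by sulforhodamine B assay, with a stated time of 48 h (a higher number here means that more compound is tolerated, a lower number that less compound is tolerated), the highest of the two numbers shown; compound 1 `Nc1cc(N)c2nc(-c3ccccc3)c(NCc3ccc(F)cc3)nc2c1` lies nearest, separated by a 1.2-fold higher number from compound 1 to compound 3 (0.09 log units; within the scatter). In this assay compound 1 gives 56200 nM. Compound 2 `Nc1cc(N)c2nc(-c3ccccc3)c(Sc3ccc(Cl)c(Cl)c3)nc2c1` yields only a limit in this assay, namely < 100000 nM. Compound 4 `Nc1cc(N)c2nc(-c3ccccc3)c(Sc3ccc(F)cc3)nc2c1` differs from compound 3 by (4-fluorophenyl)sulfanyl in place of 4-fluorophenoxy on an aromatic carbon. Going by the values given here, no measured step exchanges oxygen for sulfur while keeping the same ring; a step that the limit leaves unreadable from compound 2 to compound 3 stays unreadable because of the limit (the limit of < 100000 nM in this assay, at which 1 of the 3 values shown sits), and a 1.2-fold higher number from compound 1 to compound 3 (0.09 log units; within the scatter) is within the scatter. Compound 4 is therefore expected to show no step beyond the scatter, a 1.0-fold higher number from compound 3 to compound 4 (0.00 log units; within the scatter). The estimate for compound 4 is 70000 nM, spanning 28000 nM to 100000 nM.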

Compound 4, concentration lethal to 50% of the cells: 60300 nM
Estimate against measurement, compound 4: 1.2-fold (0.06 log units) above, and the stated range covers the measured number.
By their numbers in this assay, from the lowest: compounds 1, 4 and 3 (each within the scatter of the next).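

In this assay, going by these compounds alone, (4-fluorophenyl)sulfanyl in place of 4-fluorophenoxy gives a 1.1-fold lower number from compound 3 to compound 4 (0.06 log units; within the scatter), the only readable exchange of oxygen for sulfur with the same ring kept, so at this position that exchange moves the number no further than the scatter. Against the (4-fluorobenzyl)amino group, the same sulfur-linked group gives a 1.1-fold higher number from compound 1 to compound 4 (0.03 log units; within the scatter), which leaves compounds 1, 3 and 4 within the scatter of one another. The step from compound 2 to compound 4 cannot be read because compound 2 gives only a limit: the limit of < 100000 nM in this assay, at which 1 of the 4 values shown sits.

As far as these compounds go, whether a carbonyl in place of the sulfur, or a carboxylic acid in place of the fluorine, would move the number beyond the scatter stays open.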